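From 2-hydroxyphenyl to 5-chlorothiophen-2-yl on a sulfonyl sulfur

A few compounds are considered here, and "the series" means these few. Any claim that something is new, unique, unknown or untested is made for them only; others in the source may bear on it.

Of the compounds shown here, three sharing one core have been tested in an ADME assay on HEK293 cells (Homo sapiens) for cytotoxicity, read by resazurin assay, with a stated time of 48 h; on this read-out higher numbers stand for lower toxicity in this test and lower numbers for higher toxicity in this test. Compound 1 `Cc1ccccc1S(=O)(=O)Nc1ccc2oc(-c3ccccc3)nc2c1` gives 57000 nM. Compound 2 `O=S(=O)(Nc1ccc2oc(-c3ccccc3)nc2c1)c1cccc(O)c1` gives > 100000 nM, and this is a limit of the assay, not a number. Compound 3 `O=S(=O)(Nc1ccc2oc(-c3ccccc3)nc2c1)c1ccccc1O` gives 33000 nM. Its closest measured neighbour is compound 1, and the comparison is a 1.7-fold lower number from compound 1 to compound 3 (0.24 log units; within the scatter), so those two values cannot be told apart. The two remaining comparisons are an at least 1.7-fold higher number from compound 1 to compound 2 (0.24 log units; that floor lies within the scatter) and an at least 3.0-fold lower number from compound 2 to compound 3 (0.48 log units; beyond the scatter).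

Compound 4 `O=S(=O)(Nc1ccc2oc(-c3ccccc3)nc2c1)c1ccc(Cl)s1` has not yet been measured. It carries 5-chlorothiophen-2-yl in place of 2-hydroxyphenyl on a sulfonyl sulfur. Within the data shown here, all three measured steps change this same group, but none brings in a five-membered aromatic ring, so they indicate only how far a swap here has moved the number so far. Only one of them clearly exceeds the scatter, and they offer no direction for this new group. The expectation therefore stays close to compound 3, with no step beyond the scatter and a wide margin on both sides. The expected change is a 1.1-fold higher number from compound 3 to compound 4 (0.03 log units; within the scatter). For compound 4 the estimated value is 35000 nM, with an expected range of 12000 nM to 100000 nM.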

Compound 4, half-maximal cytotoxic concentration: > 100000 nM
Compound 4 ended at the assay's limit; the forecaster's own chance of this, stated with the estimate: 15%; middle value at least 2.8-fold (0.45 log units) from the limit.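

Swapping 2-hydroxyphenyl for 5-chlorothiophen-2-yl on the sulfonyl sulfur gives an at least 3.0-fold higher number from compound 3 to compound 4 (0.48 log units; beyond the scatter), so this position also accepts a five-membered aromatic ring with no hydrogen-bond donor and still moves the number clearly upward in this assay. Compound 4 gives > 100000 nM, which is a limit of the assay and not a number. The step against the 2-methylphenyl compound is an at least 1.7-fold higher number from compound 1 to compound 4 (0.24 log units; that floor lies within the scatter), so its floor does not separate those two compounds, and the step between the two compounds at the limit cannot be read, since neither has a true number: the limit of > 100000 nM in this assay, at which 2 of the 4 values shown sit.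

Going by these compounds, how far compound 2 and compound 4 really lie from that limit stays unknown, so the full size of the step to compound 4 is open as well. The compounds shown also cannot separate the part played by the chlorine from that of the ring, a question that plain thiophen-2-yl would address, and they say nothing about an amine or a carboxylic acid on the ring at this position.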